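Replacing a dichlorophenyl with pyridinyl on a cyanopyridine core

The source may report more compounds than this note shows. Statements on the series, on what has been measured and on what is new or still open speak of the compounds shown alone.

Compound 1, `COc1nc(-c2ccccc2)cc(-c2ccc(F)cc2)c1C#N`: 25 nM
Compound 2, `COc1nc(-c2ccccc2)cc(-c2ccc(Cl)cc2)c1C#N`: 252 nM
Compound 3, `COc1nc(-c2ccccc2)cc(-c2ccc(Cl)cc2Cl)c1C#N`: > 100000 nM

Three compounds share one core and differ only in the aryl group that sits ortho to the cyano group, as tested in an assay on isolated protein for inhibition of sulfide:quinone oxidoreductase, mitochondrial (Homo sapiens); a higher number here means a weaker inhibitor, a lower number a stronger inhibitor. Compound 1 carries a 4-fluorophenyl there and gives 25 nM. Compound 2 carries a 4-chlorophenyl and gives 252 nM; the step of a 10-fold higher number from compound 1 to compound 2 (1.00 log units; beyond the scatter) is modest. Compound 3 carries a 2,4-dichlorophenyl, and its result is only a limit of the assay, > 100000 nM, so compound 3 stands at the weak end of this set with no exact number (the limit of > 100000 nM in this assay, at which 1 of the 3 values shown sits). The steps of an at least 4000-fold higher number from compound 1 to compound 3 (3.60 log units; beyond the scatter) and an at least 390-fold higher number from compound 2 to compound 3 (2.59 log units; beyond the scatter) are both large.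

Compound 4, `COc1nc(-c2ccccc2)cc(-c2ccncc2)c1C#N`, is not yet measured. The change is pyridin-4-yl in place of 2,4-dichlorophenyl on an aromatic carbon. Since both large steps into compound 3 came with chlorines on that ring, removing them is expected to reverse much of that loss, so an at least 160-fold lower number from compound 3 to compound 4 (2.22 log units; beyond the scatter) is the expected size of the step. Compound 4 is expected to give about 600 nM, within 50 nM to 10000 nM.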

Compound 4, half-maximal inhibitory concentration: 541 nM
Compound 4: the middle estimate sits 1.1-fold (0.04 log units) above what was measured; low and high end bracket the measured number.
By their numbers in this assay, from the lowest: compound 1; then compound 2; then compound 4. At a limit, above all of these: compound 3.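

The position opposite the ring nitrogen of the shared core does not need an all-carbon aryl ring, as pyridin-4-yl restores a measurable number in place of 2,4-dichlorophenyl, with an at least 180-fold lower number from compound 3 to compound 4 (2.26 log units; beyond the scatter). Compound 3 sits at a limit in this assay and not at a number, so that step gives only a minimum size: the limit of > 100000 nM in this assay, at which 1 of the 4 values shown sits. Set against the singly substituted phenyl groups, pyridin-4-yl is a modest step from 4-chlorophenyl, with a 2.1-fold higher number from compound 2 to compound 4 (0.33 log units; beyond the scatter), but a large one from 4-fluorophenyl, with a 22-fold higher number from compound 1 to compound 4 (1.34 log units; beyond the scatter).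

The compounds shown leave open what a plain phenyl would give here, which would separate the effect of the ring nitrogen from the loss of the chlorines. Also open, from the compounds shown here alone, is how a fluoro group or an amine on the pyridin-4-yl would fare.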